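A Chloro-for-Methoxy Swap Carried onto a Second Core

The source may report more compounds than this note shows. Statements on the series, on what has been measured and on what is new or still open speak of the compounds shown alone.

Three compounds were measured in a functional assay on CHO cells for agonist activity at Alpha-1A adrenergic receptor (Homo sapiens), read by FLIPR and calcium flux; a higher number here means that more compound is needed for the effect, a lower number that less compound is needed. Compound 1 `Clc1ccccc1C1CCc2nc[nH]c2C1` gives 276 nM in this assay, compound 2 `COc1ccccc1C1CCc2nc[nH]c2C1` gives 144 nM, and compound 3 `COc1ccccc1C1Cc2nccn2C1` gives 22 nM. Compound 1 differs from compound 2 by chloro in place of methoxy on an aromatic carbon, and this change gave a 1.9-fold higher number from compound 2 to compound 1 (0.28 log units; within the scatter). Compound 3 has the lowest number of the three, beyond the scatter from both compound 2 and compound 1; the difference between its core and the core of compound 2 is not broken down here.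

Compound 4 `Clc1ccccc1C1Cc2nccn2C1` has not yet been measured in this assay. It differs from compound 3 by chloro in place of methoxy on an aromatic carbon. This is the same kind of change as that from compound 2 to compound 1, though the place is ortho to a group of 8 heavy atoms in compound 3 where it was ortho to a group of 9 heavy atoms in compound 2. Since the earlier change of this kind gave a 1.9-fold higher number from compound 2 to compound 1 (0.28 log units; within the scatter), a step of similar small size is expected here: a 1.8-fold higher number from compound 3 to compound 4 (0.26 log units; within the scatter). Compound 4 is therefore estimated at 40 nM in this assay, within a range of 15 nM to 110 nM.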

Compound 4, half-maximal effective concentration: 19 nM
For compound 4 the middle estimate is 2.1-fold (0.32 log units) above the measured one, and the stated range covers the measured number.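

In this assay, chloro in place of methoxy on an aromatic carbon gave a 1.2-fold lower number from compound 3 to compound 4 (0.06 log units; within the scatter). Set beside the earlier step on the other core, the two results cannot be told apart: the same change on two cores in this assay, a 1.9-fold higher number (0.28 log units; within the scatter) from compound 2 to compound 1 and a 1.2-fold lower number (0.06 log units; within the scatter) from compound 3 to compound 4, 2.2-fold (0.35 log units) apart, within the scatter of two such steps. The swap therefore carried from the core of compound 2 to the core of compound 3 without any difference beyond the scatter, but these two pairs do not show that it would carry to any further core, and with both steps within the scatter they do not establish that chloro and methoxy differ at this place or that they are equivalent there.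

The compounds shown leave open what a hydroxyl, a nitrile or a trifluoromethyl group would give in place of chloro and methoxy on either core. Going by these compounds, it also remains open whether an amine or a longer alkoxy chain on that aromatic carbon would keep the two cores in step.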